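A Methoxyphenyl Swap in a Weak Glucoamylase Series

The source may report more compounds than this note shows. Statements on the series, on what has been measured and on what is new or still open speak of the compounds shown alone.

In an assay on isolated protein for inhibition of Maltase-glucoamylase (Homo sapiens), with stated times of 15 min and 10 min (a higher number here means a weaker inhibitor, a lower number a stronger inhibitor), compound 1 `C=CCc1cc(-c2cc(CC=C)c3oc(SCc4nnc(-c5cccc(OC)c5)o4)nc3c2)c2oc(SCc3nnc(-c4cccc(OC)c4)o3)nc2c1` gives 24500 nM, a weak result. Compound 2 `C=CCc1cc(-c2cc(CC=C)c3oc(SCc4nnc(-c5ccc(OC)cc5)o4)nc3c2)c2oc(SCc3nnc(-c4ccc(OC)cc4)o3)nc2c1` returns "nd" (no result reported) in this assay. Compound 3 `C=CCc1cc(CSc2nnc(-c3ccc(Cl)cc3)o2)c(O)c(-c2ccc(O)c(CC=C)c2)c1` also has "nd" (no result reported) in this assay, so compound 3 stands without a single number, and one further entry in the set lacks one as well. Compound 4 `C=CCc1cc(CSc2nnc(-c3cccc(OC)c3)o2)c(O)c(-c2ccc(O)c(CC=C)c2)c1` differs from compound 3 in one place: 3-methoxyphenyl in place of 4-chlorophenyl on an aromatic carbon. Going by the values given here, no step between measured compounds is available, so for this change in this assay a shift of no more than the usual scatter is expected, in no particular direction. Only compound 1, with 24500 nM in this assay, offers a reference, and it points to weak inhibition. Compound 4 is therefore estimated at 30000 nM, with a range from 5000 nM to 200000 nM.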

Compound 4, half-maximal inhibitory concentration: 52900 nM
For compound 4 the middle estimate is 1.8-fold (0.25 log units) below the measured one, within the range that was stated.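

Going by these compounds alone, compound 3 has no single number in this assay, so no step from compound 3 to compound 4 can be read. Whether 3-methoxyphenyl in place of 4-chlorophenyl shifts inhibition stays open, and nothing shown bears on a cause.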